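The source may report more compounds than this note shows. Statements on the series, on what has been measured and on what is new or still open speak of the compounds shown alone.

Measured compounds in a functional assay on MGC-803 cells (Homo sapiens) for antiproliferative activity, read by MTT assay; a higher number here means a weaker inhibitor, a lower number a stronger inhibitor:
Compound 1 `COc1ccccc1NC(=O)Nc1cccc(CNc2ncnc3ccccc23)c1` gives 39300 nM.
Compound 2 `O=C(Nc1cccc(CNc2ncnc3ccccc23)c1)Nc1cccc(C(F)(F)F)c1` gives only a limit of the assay, > 50000 nM.
Compound 3 `COc1cc2ncnc(NCc3cccc(NC(=O)Nc4ccccc4)c3)c2cc1OC` gives 10000 nM.

Compound 3 stands lowest of the two numbers in this assay; compound 1 gives a higher number, and that gap lies beyond the scatter. Compound 2 sits at the limit of > 50000 nM in this assay, at which 1 of the 3 values shown sits, and cannot be placed against the others more closely than that.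

Compound 4 `COc1cc2ncnc(NCc3cccc(NC(=O)Nc4ccc([N+](=O)[O-])cc4)c3)c2cc1OC` is not yet measured in this assay. It differs from compound 3 by nitro in place of hydrogen on an aromatic carbon, on the phenyl carried by the urea of compound 3.

For the measured compounds named here, only one measured step touches the same phenyl: an at least 1.2-fold higher number from compound 1 to compound 2 (0.10 log units; that floor lies within the scatter). That step swaps the whole aryl rather than adding a single group, and it ends at a limit, so it gives little guidance beyond showing no gain from that change. Going by the values given here, no measured step adds a nitro anywhere.

The expected step of a 1.2-fold higher number from compound 3 to compound 4 (0.08 log units; within the scatter) is therefore none beyond the scatter, with the possibility of a weaker number in view of compound 2. Compound 4 is estimated at 12000 nM, between 3000 nM and 45000 nM.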

Compound 4, half-maximal inhibitory concentration: 8120 nM
The estimate for compound 4 lay 1.5-fold (0.17 log units) above the measured number, and the stated range covers the measured number.
By their numbers in this assay, from the lowest: compounds 4 and 3 (each within the scatter of the next); then compound 1. At a limit, above all of these: compound 2.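

In this assay, nitro in place of hydrogen on the phenyl carried by the urea, para to a large group, gives a 1.2-fold lower number from compound 3 to compound 4 (0.09 log units; within the scatter) and so leaves the number where it stood, even though the change adds a group of three heavy atoms with two hydrogen-bond acceptors. For the compounds shown here, the earlier compounds could not show this: their only step on this phenyl exchanged one substituted aryl for another and ended at a limit, whereas the present step adds a single group to the unsubstituted phenyl and is read between two numbers, so this position tolerates the 4-nitrophenyl in place of phenyl with no loss in this assay. Nothing at hand gives a reason for this lack of change.

On these data alone, how an amine or a carboxylic acid in the same place on this phenyl would read in this assay stays open, as does whether any group here can move the number beyond the scatter in either direction. Also open, as far as these compounds go, is whether nitro gives a similarly small step on the phenyl of a compound with the core of compound 1, or at another place on the ring.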